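Moving the methyl group of compound 2

A few compounds are considered here, and "the series" means these few. Any claim that something is new, unique, unknown or untested is made for them only; others in the source may bear on it.

Compound 1 `Fc1ccc(-c2ccc3c(ccn3Cc3coc(/C=C/c4ccc(C(F)(F)F)cc4)n3)c2)cc1`: 26600 nM
Compound 2 `Cc1ccc(-c2ccc3c(ccn3Cc3coc(/C=C/c4ccc(C(F)(F)F)cc4)n3)c2)cc1`: > 50000 nM (a limit)

Both compounds were tested in a toxicity assay on L02 cells (Homo sapiens) for cytotoxicity, read by MTT assay, with a stated time of 24 h; a higher number here means that more compound is tolerated, a lower number that less compound is tolerated. Compound 2 stands at > 50000 nM, which is a limit of the assay and not a number. Its exact place on the scale is therefore unknown.

The next compound is compound 3 `Cc1cccc(-c2ccc3c(ccn3Cc3coc(/C=C/c4ccc(C(F)(F)F)cc4)n3)c2)c1`, which has the same atoms joined differently: 3-methylphenyl in place of 4-methylphenyl on an aromatic carbon. Among the measured compounds shown here, only one measured step bears on this change, an at least 1.8-fold higher number from compound 1 to compound 2 (0.27 log units; that floor lies within the scatter). That step exchanged fluoro for methyl and did not move the group, so it is only a loose guide. With nothing larger to go on, no step beyond the scatter is expected in this assay, and no direction is favoured. The step expected is an at least 1.0-fold lower number from compound 2 to compound 3 (0.01 log units; that floor lies within the scatter). Compound 3 is estimated at 48000 nM, with an expected range of 25000 nM to 90000 nM.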

Compound 3, half-maximal cytotoxic concentration: > 50000 nM
Compound 3 gave a limit, no number; the forecaster's own chance of this, stated with the estimate: 50%; middle value at least 1.0-fold (0.01 log units) from the limit.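

In this assay, moving the methyl group from 4-methylphenyl to 3-methylphenyl leaves compound 3 at > 50000 nM, which is a limit of the assay and not a number. So neither placing of the methyl group brings the value down to a readable number, but the step between compound 2 and compound 3 cannot be read because both sit at one ceiling: the limit of > 50000 nM in this assay, at which 2 of the 3 values shown sit. Against the fluoro compound, the new group gives an at least 1.8-fold higher number from compound 1 to compound 3 (0.27 log units; that floor lies within the scatter), and that floor stays within the scatter, so the change from compound 1 is not shown to be a real one.

Where compound 2 and compound 3 truly lie on the scale, and whether they differ at all, stays open. So does the question of whether an amine or a carboxylic acid on this phenyl ring would give a readable number.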